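Chloro for methyl on a fused indole-type core

This account rests on a few compounds, and the source may have more. Where it says the series, first, only, none or still open, it means among the compounds named here.

Measured so far:
compound 1 `Cc1cc(OCC(=O)O)cc2ccn(Cc3ccc(O)c(C(C)C)c3)c12` — 0.26 nM
compound 2 `CC(C)c1cc(Cn2ccc3cc(OCC(=O)O)cc(Cl)c32)ccc1O` — 0.07 nM
compound 3 `Cc1cn(Cc2ccc(O)c(C(C)C)c2)c2c(C)cc(OCC(=O)O)cc12` — 0.18 nM

Of the compounds shown here, three have been measured in an assay on HeLa cells for displacement of a labelled ligand from thyroid hormone receptor beta (Homo sapiens); a higher number here means a weaker inhibitor, a lower number a stronger inhibitor. Compound 1 gives 0.26 nM, compound 2 gives 0.07 nM, and compound 3 gives 0.18 nM. Compound 3 differs from compound 1 by methyl in place of hydrogen on an aromatic carbon, and the step of a 1.4-fold lower number from compound 1 to compound 3 (0.16 log units; within the scatter) is within the scatter. From compound 1 to compound 2 the change is chloro in place of methyl on an aromatic carbon, which produced the step of a 3.7-fold lower number from compound 1 to compound 2 (0.57 log units; beyond the scatter).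

Compound 4 `Cc1cn(Cc2ccc(O)c(C(C)C)c2)c2c(Cl)cc(OCC(=O)O)cc12` is not yet measured. It differs from compound 3 by chloro in place of methyl on an aromatic carbon, the same change as from compound 1 to compound 2, at a place described in identical words. Because of a 3.7-fold lower number from compound 1 to compound 2 (0.57 log units; beyond the scatter) a step of similar size is expected here. For compound 4 the expected step is a 3.6-fold lower number from compound 3 to compound 4 (0.56 log units; beyond the scatter). This gives compound 4 an estimated 0.05 nM in this assay, with an expected range from 0.02 nM to 0.13 nM.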

Compound 4, inhibition constant: 0.09 nM
Estimate against measurement, compound 4: 1.8-fold (0.26 log units) below; the measured number falls inside the stated range.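

In this assay, chloro in place of methyl on an aromatic carbon gives a 2.0-fold lower number from compound 3 to compound 4 (0.30 log units; within the scatter), and this step does not differ from the earlier one on the other core: the same change on two cores in this assay, a 3.7-fold lower number (0.57 log units; beyond the scatter) from compound 1 to compound 2 and a 2.0-fold lower number (0.30 log units; within the scatter) from compound 3 to compound 4, 1.9-fold (0.27 log units) apart, within the scatter of two such steps. Methyl in place of hydrogen on an aromatic carbon gives a 1.3-fold higher number from compound 2 to compound 4 (0.11 log units; within the scatter), and this change also reads alike on both cores: the same change on two cores in this assay, a 1.4-fold lower number (0.16 log units; within the scatter) from compound 1 to compound 3 and a 1.3-fold higher number (0.11 log units; within the scatter) from compound 2 to compound 4, 1.9-fold (0.27 log units) apart, within the scatter of two such steps. Going by these compounds alone, this agreement fits both changes carrying from one core to the other, but it rests on only two pairs per change and does not show that chloro for methyl gives a real gain on the core of compound 3, where its step stays within the scatter.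

The compounds shown leave open whether bromo or methoxy on that aromatic carbon would follow chloro. They also leave open whether the steps would hold if a longer carboxylic acid chain replaced the carboxymethoxy group.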